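From ethoxycarbonyl to 4-fluorophenyl: compound 2 to compound 3

The compounds below may be only part of what the source reports. "The series", "measured", "known", "first", "only" and "open" are said of these compounds alone.

Compound 1 `C=C[C@@](C)(/C=C/c1ccc(OS(=O)(=O)C(F)(F)F)cc1)CCC=C(C)C`: > 52000 nM (a limit)
Compound 2 `C=C[C@@](C)(/C=C/c1ccc(O)c(/C=C/C(=O)OCC)c1)CCC=C(C)C`: > 52000 nM (a limit)

In a functional assay on HepG2 cells (Homo sapiens) for cytotoxicity, with a stated time of 72 h (a higher number here means that more compound is needed for the effect, a lower number that less compound is needed), compound 2 stands at the limit of > 52000 nM in this assay, at which 2 of the 2 values shown sit. It therefore has a limit and no number, and compound 1 offers no number to compare it with.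

Compound 3 `C=C[C@@](C)(/C=C/c1ccc(O)c(/C=C/c2ccc(F)cc2)c1)CCC=C(C)C` has not yet been measured. It differs from compound 2 by one change: 4-fluorophenyl in place of ethoxycarbonyl on a double-bonded chain carbon bound to a double-bonded chain carbon. For the measured compounds named here, no measured step between compounds gives a guide to the size of such a change. In this assay, only a modest shift towards less compound being needed is expected, and it may stay within the scatter. The expected change is an at least 1.3-fold lower number from compound 2 to compound 3 (0.11 log units; that floor lies within the scatter). For compound 3 the estimated value is 40000 nM, with an expected range of 15000 nM to 70000 nM.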

Compound 3, half-maximal effective concentration: > 52000 nM
Compound 3: only a limit was reported; the forecaster's own chance of this, stated with the estimate: 55%; middle value at least 1.3-fold (0.11 log units) away from the limit.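

For the compounds shown here, compound 3 gives > 52000 nM in this assay, a limit and not a number; compound 2 also has only a limit, so no step between them can be read. The compounds shown leave open whether 4-fluorophenyl in place of ethoxycarbonyl changes the read-out at all.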